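Cytotoxicity notes on the amine swap in this series

The compounds below may be only part of what the source reports. "The series", "measured", "known", "first", "only" and "open" are said of these compounds alone.

Going by the values given here, compound 3 `CN(C)[C@H]1CCN(c2cccc3nc(CN(C)[C@H]4CCCc5cccnc54)cn23)C1` gives 2100 nM in an ADME assay on HOS cells (Homo sapiens) for cytotoxicity (a higher number here means that more compound is tolerated, a lower number that less compound is tolerated), and stands at the low end of the three numbers so far. Compound 2 `CN(C)C1CCN(c2cccc3nc(CN(C)[C@H]4CCCc5cccnc54)cn23)CC1` gives 3400 nM, and compound 1 `CN(C)[C@@H]1CCN(c2cccc3nc(CN(C)[C@H]4CCCc5cccnc54)cn23)C1` gives 4900 nM. The step of a 2.3-fold lower number from compound 1 to compound 3 (0.37 log units; beyond the scatter) is modest and rests on (the fact that compounds 1 and 3 differ only in the configuration as drawn). Compound 4 `CCN1CCN(c2cccc3nc(CN(C)[C@H]4CCCc5cccnc54)cn23)CC1` carries the change (4-ethylpiperazin-1-yl in place of 3-(dimethylamino)pyrrolidin-1-yl on an aromatic carbon). The two earlier exchanges of one saturated amine ring for another, a 1.4-fold lower number from compound 1 to compound 2 (0.16 log units; within the scatter) and a 1.6-fold lower number from compound 2 to compound 3 (0.21 log units; within the scatter), both stayed within the scatter, so in this assay no step beyond the scatter is expected from this change in either direction. Compound 4 is therefore estimated at 2700 nM, within 1100 nM to 6500 nM, which means an expected step of a 1.3-fold higher number from compound 3 to compound 4 (0.11 log units; within the scatter).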

Compound 4, half-maximal cytotoxic concentration: 3900 nM
Compound 4: middle estimate off by 1.4-fold (0.16 log units), on the low side; measured number inside the range.
By their numbers in this assay, from the lowest: compounds 3, 2, 4 and 1 (each within the scatter of the next, the first and the last beyond it).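

In this assay, 4-ethylpiperazin-1-yl at this position stays within the scatter of all three earlier amines (a 1.9-fold higher number from compound 3 to compound 4 (0.27 log units; within the scatter); a 1.1-fold higher number from compound 2 to compound 4 (0.06 log units; within the scatter); a 1.3-fold lower number from compound 1 to compound 4 (0.10 log units; within the scatter)). A six-membered ring with 2 hetero atoms and no defined stereocentre therefore gives a number that cannot be separated from those of compound 1 or compound 3, although those two lie apart. Nothing at hand accounts for these steps.

Open, on these data alone, is whether a different group on this aromatic carbon, such as a morpholine ring or a carboxylic acid, would move the number beyond the scatter.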